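A Fluorine Swap Tried on a Second Core

The source may report more compounds than this note shows. Statements on the series, on what has been measured and on what is new or still open speak of the compounds shown alone.

In a functional assay on A549 cells (Homo sapiens) for inhibition, read by sulforhodamine B assay, with a stated time of 48 h, tested at 100 uM (a higher number here means more inhibition of growth at the concentration tested, a lower number less inhibition of growth), compound 2 `O=c1c(C2N=C(c3ccccc3)SS2)coc2ccccc12` gives 42%, while compound 1 `O=c1c(C2N=C(c3ccccc3)SS2)coc2ccc(F)cc12` gives 55%. The change between them, (fluoro in place of hydrogen on an aromatic carbon), made a step of a number 13 percentage points higher from compound 2 to compound 1 (beyond the scatter). Compound 3 `O=c1c(C(=S)Nc2ccccc2)coc2ccccc12` carries a different group on the shared core; the difference between the two cores is not broken down here. In this assay compound 3 gives 79%, the highest of the three. Compound 4 `O=c1c(C(=S)Nc2ccccc2)coc2ccc(F)cc12` differs from compound 3 by fluoro in place of hydrogen on an aromatic carbon, the same change as that between compound 2 and compound 1, at the same place. The expectation rests on that single earlier step, a number 13 percentage points higher from compound 2 to compound 1 (beyond the scatter), and on the high starting point of compound 3. A step of about a number 7 percentage points higher from compound 3 to compound 4 (within the scatter) is expected, tempered somewhat since the read-out cannot exceed full inhibition. Compound 4 is expected to give 86%.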

Compound 4, percent growth inhibition at one concentration: 70%
Compound 4: the middle estimate sits 16 percentage points above what was measured; the measured number lies below the stated range.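

On the thioamide-bearing core, fluoro in place of hydrogen on an aromatic carbon gives a number 9 percentage points lower from compound 3 to compound 4 (within the scatter) in this assay, a step too small to tell apart from the ordinary spread of repeated measurements. The gain seen on the other core therefore did not carry over, and the two steps differ: the same change on two cores in this assay, a number 13 percentage points higher (beyond the scatter) from compound 2 to compound 1 and a number 9 percentage points lower (within the scatter) from compound 3 to compound 4, 22 percentage points apart, beyond the scatter of two such steps. Among the compounds shown here, this shows that one core's result is a poor guide to the other's here, but with only two pairs, it does not explain the difference or predict the result on a third core.

The compounds shown leave open how a chloro, a methoxy or an amine at the same place would behave on either core. They also leave open whether fluoro on another carbon of that ring would give the same steps.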